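A few compounds are considered here, and "the series" means these few. Any claim that something is new, unique, unknown or untested is made for them only; others in the source may bear on it.

Measured in a functional assay on MCF7 cells (Homo sapiens) for antiproliferative activity, read by MTT assay, with a stated time of 72 h; a lower number here means a stronger inhibitor, a higher number a weaker inhibitor:
- compound 1 `C#CCSc1nc(Sc2ccccn2)c(C#N)c(-c2cc(OC)c(OC)c(OC)c2)n1`: > 10000 nM
- compound 2 `C#CCSc1nc(Sc2nc[nH]n2)c(C#N)c(-c2cc(OC)c(OC)c(OC)c2)n1`: > 20000 nM

Both entries are limits and not numbers. Going by the values given here, compound 2 stands at > 20000 nM, which is a limit, and the only other value available is also a limit, so compound 2 cannot be placed on a scale.

Compound 3 `C#CCSc1nc(Sc2nc3ccccc3s2)c(C#N)c(-c2cc(OC)c(OC)c(OC)c2)n1` has 1,3-benzothiazol-2-yl in place of 1H-1,2,4-triazol-3-yl on a sulfur. Among the compounds with values here, the same place was changed in the only measured step, a step that the two limits leave unreadable from compound 1 to compound 2. Within the data shown here, that step gives neither a size nor a direction to carry over, and no other measured step bears on the change.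

Among the measured compounds shown here, with a step that the two limits leave unreadable from compound 1 to compound 2 as the only guide, no particular direction can be expected in this assay, and compound 3 may well also be reported as a limit. The expected at least 1.3-fold lower number from compound 2 to compound 3 (0.12 log units; that floor lies within the scatter) is therefore a loose estimate. For compound 3 the estimated value is 15000 nM, with an expected range of 4000 nM to 40000 nM.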

Compound 3, half-maximal inhibitory concentration: > 20000 nM
Compound 3: a limit, no number; the forecaster's own chance of this, stated with the estimate: 65%; middle value at least 1.3-fold (0.12 log units) away from the limit.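

In this assay compound 3 gives > 20000 nM, a limit and not a number. The steps to compound 3 from compound 1 and from compound 2 cannot be read, because all of these results are limits: the limit of > 20000 nM in this assay, at which 2 of the 3 values shown sit.

The compounds shown leave open how pyridin-2-yl, 1H-1,2,4-triazol-3-yl and 1,3-benzothiazol-2-yl on the sulfur rank against one another.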